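A few compounds are considered here, and "the series" means these few. Any claim that something is new, unique, unknown or untested is made for them only; others in the source may bear on it.

Measured compounds in a functional assay on the whole organism (strain albino) with Mus musculus as the target, with a stated time of 0.5 h; a higher number here means that more compound is needed for the effect, a lower number that less compound is needed:
compound 1 `O=C(CCCN1C(=O)c2ccccc2C1=O)Nc1ccc(Br)cc1` — 30 mg/kg
compound 2 `CCc1ccc(NC(=O)CCCN2C(=O)c3ccccc3C2=O)cc1` — 100 mg/kg

For the measured compounds named here, compound 2 stands at the higher of the two numbers so far; its nearest neighbour is compound 1, and the step of a 3.3-fold higher number from compound 1 to compound 2 (0.52 log units; beyond the scatter) lies beyond the scatter, so compound 2 needs more compound than compound 1 for the same effect.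

The next compound, compound 3 `Cc1cc(Cl)ccc1NC(=O)CCCN1C(=O)c2ccccc2C1=O`, differs from compound 2 in one place: 4-chloro-2-methylphenyl in place of 4-ethylphenyl on an amide-type nitrogen. Going by the values given here, the only measured step that bears on this is a 3.3-fold higher number from compound 1 to compound 2 (0.52 log units; beyond the scatter), where bromo gave way to ethyl on the aromatic carbon and the number rose. Among the compounds with values here, compound 3 returns a halogen to the ring, which compound 1 carries and compound 2 does not, while adding a methyl for which no measured step exists. The ethyl-to-halogen direction therefore suggests a lower number than compound 2, though the methyl leaves the size uncertain. Compound 3 is expected at 50 mg/kg, with a range of 20 mg/kg to 150 mg/kg, a step of a 2.0-fold lower number from compound 2 to compound 3 (0.30 log units; within the scatter).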

Compound 3, minimum effective dose: 100 mg/kg
The estimate for compound 3 lay 2.0-fold (0.30 log units) below the measured number; low and high end bracket the measured number.
By their numbers in this assay, from the lowest: compound 1; then compounds 2 and 3 (each within the scatter of the next).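

In this assay, replacing 4-ethylphenyl with 4-chloro-2-methylphenyl on the amide-type nitrogen gives no change at the digits printed from compound 2 to compound 3 (within the scatter), so at this position these two groups cannot be told apart by this read-out. Chlorine on the ring does not bring the number back to that of the bromo compound: the change from 4-bromophenyl to 4-chloro-2-methylphenyl gives a 3.3-fold higher number from compound 1 to compound 3 (0.52 log units; beyond the scatter), a step of modest size, and compound 3 therefore goes against any reading that a halogen on the ring alone goes with the lower number. No measurement on these compounds accounts for either step.

On these data alone, the separate contributions of the chlorine and the methyl remain open, and a 4-chlorophenyl group or a plain phenyl group on the same nitrogen would be needed to separate them. Also open, as far as these compounds go, is whether compound 1 marks a real preference for 4-bromophenyl that would hold with an amine or a carboxylic acid on the ring, or with a longer chain between the amide carbonyl and the shared core.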